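A Dichloropyridazinyl Ether in Place of the Benzimidazolyl Group

The source may hold more compounds than are shown below. What is called first, only, known or untested is meant among the compounds shown, and "the series" means these compounds.

Three measured compounds share one core. Compound 1 `COC(=O)c1cc(OCC(=O)[C@H](CC(=O)O)NC(=O)[C@@H](NC(=O)COc2cccc3ccccc23)C(C)C)no1` gives 71000 nM in a functional assay on Jurkat cells (Homo sapiens) for inhibition; on this read-out higher numbers stand for weaker inhibition and lower numbers for stronger inhibition. Compound 2 `CC(C)[C@H](NC(=O)COc1cccc2ccccc12)C(=O)N[C@@H](CC(=O)O)C(=O)CSc1nncn1C` reaches only the limit of this assay, > 200000 nM. Compound 3 `CC(C)[C@H](NC(=O)COc1cccc2ccccc12)C(=O)N[C@@H](CC(=O)O)C(=O)COc1nc2ccccc2[nH]1` likewise stops at the limit, > 200000 nM. Compound 3 therefore stands at the weak end of the numbers shown, sharing the limit of > 200000 nM in this assay, at which 2 of the 3 values shown sit, with compound 2. The step of an at least 2.8-fold higher number from compound 1 to compound 3 (0.44 log units; beyond the scatter) shows that the (1H-benzimidazol-2-yl)oxy group falls well behind compound 1, while the step that the two limits leave unreadable from compound 2 to compound 3 cannot be sized. Compound 4 `CC(C)[C@H](NC(=O)COc1cccc2ccccc12)C(=O)N[C@@H](CC(=O)O)C(=O)COc1nncc(Cl)c1Cl` differs from compound 3 by 4,5-dichloropyridazin-3-yl in place of 1H-benzimidazol-2-yl on an oxygen on a saturated carbon. For the measured compounds named here, no measured step describes this exact exchange; the two steps that bear on this part of the molecule, an at least 2.8-fold higher number from compound 1 to compound 2 (0.44 log units; beyond the scatter) and an at least 2.8-fold higher number from compound 1 to compound 3 (0.44 log units; beyond the scatter), both run from compound 1 into the limit. Compound 4 is therefore expected to remain weak, with the step of an at least 1.6-fold lower number from compound 3 to compound 4 (0.22 log units; that floor lies within the scatter) expected to be small and possibly not readable in this assay. Compound 4 is estimated at 120000 nM, within 30000 nM to 400000 nM in this assay.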

Compound 4, half-maximal inhibitory concentration: > 200000 nM
Compound 4 gave a limit, no number (the forecaster's own chance of this, stated with the estimate: 55%); middle value at least 1.6-fold (0.22 log units) from the limit.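

In this assay, for the compounds shown here, compound 4 also gives a limit and not a number, so a single six-membered aromatic ring with 2 hetero atoms and 0 hydrogen-bond donors reads no differently here from the two-ring 1H-benzimidazol-2-yl group of compound 3: the limit of > 200000 nM in this assay, at which 3 of the 4 values shown sit. The step of an at least 2.8-fold higher number from compound 1 to compound 4 (0.44 log units; beyond the scatter) now gives a third exchange at this oxygen-linked or sulfur-linked position that moves away from compound 1, leaving compound 1 as the only compound of the four with a number. The steps among compound 2, compound 3 and compound 4 cannot be read, as each joins two limits.

As far as these compounds go, it remains open whether the methoxycarbonyl group of compound 1 is what sets compound 1 apart from compound 2, compound 3 and compound 4, or whether a carboxylic acid or an amine in its place on the 1,2-oxazole would keep a readable number. From the compounds shown here alone, how far compound 2, compound 3 and compound 4 differ from one another also stays unknown.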